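The source may hold more compounds than are shown below. What is called first, only, known or untested is meant among the compounds shown, and "the series" means these compounds.

The three measured compounds share one core and differ only in the groups attached to it. Compound 1 `CCCc1cnc(N2CCC(C3Cc4c(F)c(C5=CCN(S(=O)(=O)CCC)CC5)cc(F)c4O3)CC2)nc1` carries a plain propyl chain on the sulfonyl sulfur and two fluoro groups on the aromatic ring; in a functional assay on HEK293 cells with Glucose-dependent insulinotropic receptor (Homo sapiens) as the target, read by cAMP accumulation, with a stated time of 60 min (a lower number here means a smaller maximal response, a higher number a larger maximal response), compound 1 gives 119%. Compound 2 `CCCc1cnc(N2CCC(C3Cc4cc(C5=CCN(S(=O)(=O)CCCO)CC5)cc(F)c4O3)CC2)nc1` has a hydroxy on that chain and a single fluoro, and compound 2 gives 92%. Compound 3 `CCCc1cnc(N2CCC(C3Cc4c(F)c(C5=CCN(S(=O)(=O)CCCO)CC5)cc(F)c4O3)CC2)nc1` combines both features, and compound 3 gives 86%, the lowest of the three numbers, though its gap to compound 2 lies within the usual scatter while its gap to compound 1 lies beyond it. The two steps leading to it read a number 33 percentage points lower from compound 1 to compound 3 (beyond the scatter) and a number 6 percentage points lower from compound 2 to compound 3 (within the scatter).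

Compound 4 `CCCc1cnc(N2CCC(C3Cc4c(F)c(C5=CCN(S(=O)(=O)CCC(C)(C)O)CC5)cc(F)c4O3)CC2)nc1` is not yet measured. It differs from compound 3 in one place: 1-hydroxy-1-methylethyl in place of hydroxymethyl on a saturated chain carbon, two bonds along the chain from a sulfonyl sulfur The hydroxy stays, and the chain grows from hydroxymethyl to 1-hydroxy-1-methylethyl. Among the compounds with values here, only the step from compound 1 to compound 3 touched this part of the molecule, and it was large; the fluoro step does not bear on the change. Within the data shown here, no measured pair shows what the added methyl groups do. Because the hydroxy introduced in a number 33 percentage points lower from compound 1 to compound 3 (beyond the scatter) remains in compound 4, the maximal response is expected to stay close to that of compound 3, with a number 4 percentage points higher from compound 3 to compound 4 (within the scatter) expected to be small and not beyond the scatter. Compound 4 is therefore estimated at 90%, in a range from 70% to 110%.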

Compound 4, largest response reached (Emax), in percent of the reference or control that the assay uses: 82%
Compound 4: the middle estimate sits 8 percentage points above what was measured; the measured number falls inside the stated range.
By their numbers in this assay, from the lowest: compounds 4, 3 and 2 (each within the scatter of the next); then compound 1.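

In this assay, the swap at this place, on a saturated chain carbon, two bonds along the chain from a sulfonyl sulfur, gives a number 4 percentage points lower from compound 3 to compound 4 (within the scatter), so 1-hydroxy-1-methylethyl and hydroxymethyl cannot be told apart here by maximal response. Within the data shown here, measured against the plain chain, the same group gives a number 37 percentage points lower from compound 1 to compound 4 (beyond the scatter), which means that a second hydroxy-bearing chain, larger than the first, also stands well under compound 1, and the low response is not tied to the one chain in compound 3. Nothing available explains why a hydroxy-bearing chain goes with the lower response in these compounds.

The compounds shown leave open whether the hydroxy itself matters or whether a methoxy, an amine or a carboxylic acid in its place would give a response like that of compound 1 or like those of compound 3 and compound 4. They also leave open whether 1-hydroxy-1-methylethyl behaves the same way on the single-fluoro core of compound 2, and whether a longer chain carrying the hydroxy would stay in this range.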